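Trimethoxyphenyl in Place of Hydroxy-Methoxyphenyl on a Chalcone

The source may report more compounds than this note shows. Statements on the series, on what has been measured and on what is new or still open speak of the compounds shown alone.

Measured so far:
Compound 1, `COc1cc(/C=C/C(=O)c2cccc(-n3cc(-c4ccc(Cl)cc4)[nH]c3=O)c2)cc(OC)c1OC`, gives 5960 nM in a functional assay on Hs-578T cells (Homo sapiens) for inhibition; on this read-out lower numbers stand for stronger inhibition of growth and higher numbers for weaker inhibition of growth.
Compound 2, `COc1ccc(-c2cn(-c3cccc(C(=O)/C=C/c4ccc(O)c(OC)c4)c3)c(=O)[nH]2)cc1`, gives 4250 nM in this assay.

Compound 2 shows the lower of these two numbers, but compound 1 lies within the usual scatter of it, so on the numbers shown the two cannot be told apart. Compound 3, `COc1ccc(-c2cn(-c3cccc(C(=O)/C=C/c4cc(OC)c(OC)c(OC)c4)c3)c(=O)[nH]2)cc1`, has not yet been measured. It differs from compound 2 in one place: 3,4,5-trimethoxyphenyl in place of 4-hydroxy-3-methoxyphenyl on a double-bonded chain carbon bound to a double-bonded chain carbon. Within the data shown here, the same trimethoxyphenyl group already appears in compound 1, which however differs from compound 3 at another position as well, so no measured pair shows the effect of this single change on its own. With compound 1 at 5960 nM and compound 2 at 4250 nM sitting within the scatter of each other despite two points of difference, there is no sign that this part of the molecule moves the read-out far. The step of a 1.2-fold higher number from compound 2 to compound 3 (0.07 log units; within the scatter) is therefore expected to stay within the scatter, with no clear direction. Compound 3 is expected to give 5000 nM in this assay, with a range from 2000 nM to 12500 nM.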

Compound 3, concentration for 50% growth inhibition: 3390 nM
Estimate against measurement, compound 3: 1.5-fold (0.17 log units) above; the measured number falls inside the stated range.
By their numbers in this assay, from the lowest: compounds 3, 2 and 1 (each within the scatter of the next).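

In this assay, 3,4,5-trimethoxyphenyl in place of 4-hydroxy-3-methoxyphenyl on a double-bonded chain carbon bound to a double-bonded chain carbon gives a 1.3-fold lower number from compound 2 to compound 3 (0.10 log units; within the scatter) and so cannot be told apart from no change, even though the entering group has 12 heavy atoms against 9 and 0 hydrogen-bond donors against 1. The result also provides a second clean comparison, since methoxy in place of chloro on an aromatic carbon gives a 1.8-fold lower number from compound 1 to compound 3 (0.25 log units; within the scatter) and likewise stays too small to read as a real difference. Neither single change therefore shows that its position moves this read-out, and no measurement offered here explains why.

Among these compounds, only two groups have been seen at each of these two places, so it remains open whether an amine, a carboxylic acid or a longer chain at either place would shift the number beyond the scatter. On these data alone, it also remains open whether the same flat picture would hold on cells other than those in this one assay.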